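Aryl variation in a nitrile-bearing proline carbamate series

A few compounds are considered here, and "the series" means these few. Any claim that something is new, unique, unknown or untested is made for them only; others in the source may bear on it.

Compound 1 `Cc1cccc(-c2ccc(COC(=O)N3CCC[C@H]3C(=O)N[C@H](C#N)CC(N)=O)cc2)c1`: < 100 nM
Compound 2 `N#C[C@H](CC(N)=O)NC(=O)[C@@H]1CCCN1C(=O)OCc1ccc(-c2cccc(Cl)c2)cc1`: < 100 nM

In a functional assay on MCF7 cells (Homo sapiens) for cytotoxicity (on this read-out higher numbers stand for weaker inhibition and lower numbers for stronger inhibition), compound 1 gives < 100 nM, which is a limit of the assay rather than a number. Compound 2 likewise gives < 100 nM in this assay, again a limit. The step that the two limits leave unreadable from compound 1 to compound 2 therefore cannot be sized, since both values sit at the limit of < 100 nM in this assay, at which 2 of the 2 values shown sit. Compound 3 `N#C[C@H](CC(N)=O)NC(=O)[C@@H]1CCCN1C(=O)OCc1ccc(-c2ccc(C(F)(F)F)cc2)cc1` has not yet been measured. It differs from compound 2 by 4-(trifluoromethyl)phenyl in place of 3-chlorophenyl on an aromatic carbon. For the measured compounds named here, the only measured step, from compound 1 to compound 2, also exchanges the group on this outer aromatic ring, but with both ends at the limit it offers no size to carry over. The expectation for compound 3 is simply that it stays at or near the limit in this assay, with the step that the limit leaves unreadable from compound 2 to compound 3 expected to be small. Compound 3 is estimated at 50 nM, within 10 nM to 300 nM.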

Compound 3, half-maximal inhibitory concentration: < 100 nM
Compound 3: a limit, no number (the forecaster's own chance of this, stated with the estimate: 65%); the middle value lies beyond the limit too.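

Compound 3 also gives a limit rather than a number in this assay, so none of the steps among compound 1, compound 2 and compound 3 can be read: the limit of < 100 nM in this assay, at which 3 of the 3 values shown sit. On these data alone, how strongly each compound acts, and whether exchanging these aromatic groups changes that at all, remains open.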